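The compounds below may be only part of what the source reports. "The series", "measured", "known", "first", "only" and "open" are said of these compounds alone.

In a functional assay on K562 cells (Homo sapiens) for inhibition, read by sulforhodamine B assay, with a stated time of 48 h (a higher number here means a weaker inhibitor of growth, a lower number a stronger inhibitor of growth), compound 1 `CCOC(=O)c1nn(-c2ccccc2)c(-c2ccc(F)cc2)c1CNC(C)(C)C` gives 75700 nM; 161000 nM (2 entries). Compound 2 `CCOC(=O)c1nn(-c2ccccc2)c(-c2ccc(Br)cc2)c1CNC(C)(C)C` gives 22000 nM; > 509000 nM (2 entries). Compound 3 `CC(C)(C)NCc1c(C(=O)O)nn(-c2ccccc2)c1-c1ccc(F)cc1` gives > 680000 nM, which is a limit and not a number. Two further entries for compound 3 provide no single number either, so its position is known only as a limit.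

Compound 4 `CC(C)(C)NCc1c(C(=O)O)nn(-c2ccccc2)c1-c1ccc(Br)cc1` has not yet been measured. It differs from compound 3 by one substitution, bromo in place of fluoro on an aromatic carbon, para to a large group. Going by the values given here, no measured pair shows this change on its own, so its size cannot be read directly from the data. The entries of compound 2 offer little guidance, as the several entries of compound 2 in this assay, 22000 nM; > 509000 nM (2 entries) combine a number with a limit.

In this assay, no step beyond the usual scatter is expected, and no direction can be set with confidence. This expectation starts from compound 3 at > 680000 nM, a limit. The expected change is small, with an estimated at least 1.3-fold lower number from compound 3 to compound 4 (0.13 log units; that floor lies within the scatter), and the assay may well report only a limit. The estimated value for compound 4 is 500000 nM, with an expected range from 150000 nM to 900000 nM.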

Compound 4, concentration for 50% growth inhibition: > 585000 nM
Compound 4 was reported as a limit; the forecaster's own chance of this, stated with the estimate: 70%; middle value at least 1.1-fold (0.06 log units) away from the limit.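

No new step can be read between compound 3 and compound 4: in this assay, both are reported only as limits, not as numbers, so the two results cannot be compared. The compounds shown leave open whether the change from 4-fluorophenyl to 4-bromophenyl alters growth inhibition at all, and if so, in which direction and by how much.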